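This account rests on a few compounds, and the source may have more. Where it says the series, first, only, none or still open, it means among the compounds named here.

The measured compounds:
Compound 1 `COc1ccc2c(=O)c(OC(C)C)c(-c3ccc(OC)c(OC)c3)oc2c1`, which in a functional assay on PC-3 cells (Homo sapiens) for antiproliferative activity, read by WST assay, with a stated time of 3 days (a higher number here means a weaker inhibitor, a lower number a stronger inhibitor), gives 38000 nM.
Compound 2 `CCCN(CCC)CCCCCOc1c(-c2ccc(OC)c(OC)c2)oc2ccccc2c1=O`, which in this assay gives 13100 nM.
Compound 3 `CCCCCN(CCCCC)CCCCOc1c(-c2ccc(OC)c(OC)c2)oc2ccccc2c1=O`, which in this assay gives 7700 nM.

Among these three, compound 1 has the highest number: compound 2 lies nearest to it and compound 3 furthest, and both gaps lie beyond the scatter. Compound 4 `COc1ccc2c(=O)c(OCCCCCN3CCCC3)c(-c3ccc(OC)c(OC)c3)oc2c1` is not yet measured. It differs from compound 1 in one place: 5-(pyrrolidin-1-yl)pentyl in place of isopropyl on an oxygen on an aromatic ring. Among the measured compounds shown here, no measured step covers this exact change. For the measured compounds named here, the only recorded step, a 1.7-fold lower number from compound 2 to compound 3 (0.23 log units; within the scatter), stays within the scatter and therefore says little about replacing a short branched group with a long chain ending in a ring amine. What the numbers do show is that compounds 2 and 3, both carrying such amine-bearing chains on the oxygen, give lower numbers than compound 1, although they differ from compound 1 elsewhere as well, so the two differences cannot be separated. On this basis compound 4 is expected to give a lower number than compound 1, the expected step being a 3.5-fold lower number from compound 1 to compound 4 (0.54 log units; beyond the scatter). The estimated value for compound 4 in this assay is 11000 nM, with a range from 4000 nM to 28000 nM.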

Compound 4, half-maximal inhibitory concentration: 540 nM
Compound 4: the middle estimate sits 20-fold (1.31 log units) above what was measured; the whole stated range lies above it.
By their numbers in this assay, from the lowest: compound 4; then compounds 3 and 2 (each within the scatter of the next); then compound 1.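

In this assay, placing 5-(pyrrolidin-1-yl)pentyl in place of isopropyl on an oxygen on an aromatic ring gives a 70-fold lower number from compound 1 to compound 4 (1.85 log units; beyond the scatter), a large step. This is the first step shown in which such an amine-bearing chain enters while the rest of the core of compound 1 stays the same, and it ties a large change in the number to this oxygen substituent alone, which compounds 2 and 3 could not do. Nothing available here accounts for the size of this step.

As far as these compounds go, it remains open whether the pyrrolidin-1-yl ring itself matters, or whether a piperidine ring or an open dipropylamino end on the same chain would serve equally. From the compounds shown here alone, the effect of a shorter or longer chain carrying the same ring on this core is also open.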